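Amide Replacement in a Cholesterol Transporter Binding Series

The source may hold more compounds than are shown below. What is called first, only, known or untested is meant among the compounds shown, and "the series" means these compounds.

Compound 1 `CCOC(=O)C1CCN(C(=O)CN2CN(c3ccccc3)C3(CCN(C(=O)c4ccc(C5CCCCC5)cc4)CC3)C2=O)CC1` in an assay on HEK293 cells for displacement of a labelled ligand from NPC1-like intracellular cholesterol transporter 1 (Homo sapiens) (a higher number here means a weaker inhibitor, a lower number a stronger inhibitor), gives 900 nM.
Compound 2 `COC(=O)CCCNC(=O)CN1CN(c2ccccc2)C2(CCN(C(=O)c3ccc(C4CCCCC4)cc3)CC2)C1=O` in this assay gives 2500 nM.
Compound 3 `COC(=O)CCCNC(=O)CN1CN(c2ccccc2)C2(CCN(C(=O)c3ccc(C(C)(C)C)cc3)CC2)C1=O` in this assay gives "not determined" (no result reported), that is, no result.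

Compound 1 and compound 2 share a core and differ only by 4-(ethoxycarbonyl)piperidin-1-yl in place of (3-(methoxycarbonyl)propyl)amino on a carbonyl carbon. This change produced a 2.8-fold lower number from compound 2 to compound 1 (0.44 log units; beyond the scatter). Compound 3 differs from compound 2 in its core by tert-butyl in place of cyclohexyl on an aromatic carbon, and no number for compound 3 in this assay exists. Compound 4 `CCOC(=O)C1CCN(C(=O)CN2CN(c3ccccc3)C3(CCN(C(=O)c4ccc(C(C)(C)C)cc4)CC3)C2=O)CC1` differs from compound 3 by 4-(ethoxycarbonyl)piperidin-1-yl in place of (3-(methoxycarbonyl)propyl)amino on a carbonyl carbon, which is the same change, at the same place, as that from compound 2 to compound 1. Within the data shown here, for compound 4 a step of a size like a 2.8-fold lower number from compound 2 to compound 1 (0.44 log units; beyond the scatter) relative to compound 3 is expected, but with compound 3 unmeasured the only anchor is compound 1 with 900 nM, so the range is kept wide. Compound 4 is estimated at 1300 nM, expected to lie between 400 nM and 4500 nM.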

Compound 4, half-maximal inhibitory concentration: 3100 nM
Beside the measured number, compound 4's estimate is 2.4-fold (0.38 log units) below it; low and high end bracket the measured number.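

With 4-(ethoxycarbonyl)piperidin-1-yl held fixed in this assay, tert-butyl in place of cyclohexyl on an aromatic carbon gives a 3.4-fold higher number from compound 1 to compound 4 (0.54 log units; beyond the scatter). This shows that the two cores differ beyond the scatter when they carry this group, but it does not show whether the change from (3-(methoxycarbonyl)propyl)amino to 4-(ethoxycarbonyl)piperidin-1-yl carries over from one core to the other: compound 3 has no number, so the step from it to compound 4 cannot be read. Nothing on hand accounts for the size of the new step.

On these data alone, whether a carboxylic acid in place of the ethyl ester of 4-(ethoxycarbonyl)piperidin-1-yl would shift the number in this assay remains open. So does the outcome of a phenyl group in place of cyclohexyl on the aromatic carbon.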